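A Pyridyl for Chlorophenyl Swap in an HDAC6 Series

The source may report more compounds than this note shows. Statements on the series, on what has been measured and on what is new or still open speak of the compounds shown alone.

Of the compounds shown here, three have been measured in an assay on Sf9 cells for inhibition of protein deacetylase HDAC6 (Homo sapiens), read by fluorescence, with a stated time of 40 min, tested at 100 nM; on this read-out higher numbers stand for more inhibition at the one concentration tested (going by the name of the read-out) and lower numbers for less inhibition. Compound 1 `O=C(NO)c1ccc(NCc2nc(-c3cccc(Cl)c3)nn2-c2ccccc2)cc1` gives 61.2% in this assay. Compound 2 `COc1ccc(-n2nc(-c3ccc(O)cc3)nc2CNc2ccc(C(=O)NO)cc2)cc1` gives 70.3%, and compound 3 `CC(C)c1ccc(-n2nc(-c3ccccc3)nc2CNc2ccc(C(=O)NO)cc2)cc1` gives 52.6%. The number for compound 1 is the middle one of the three, but both gaps are within the usual scatter: the nearest neighbour is compound 3 and the furthest is compound 2, and neither can be told apart from compound 1 with confidence. The measured compounds also differ among themselves in several places at once, so no single structural change has been followed in isolation.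

Compound 4 `O=C(NO)c1ccc(NCc2nc(-c3ccccn3)nn2-c2ccccc2)cc1` has not yet been measured. It differs from compound 1 in one place: pyridin-2-yl in place of 3-chlorophenyl on an aromatic carbon. Among the compounds with values here, no measured pair isolates an exchange of this kind, so there is nothing to show how large a shift it brings. Since the three measured compounds, despite their several differences, all sit within the scatter of one another, a large step is not anticipated. The expected step is a number 3.2 percentage points lower from compound 1 to compound 4 (within the scatter), that is, none beyond the scatter in either direction. Compound 4 is estimated to give about 58% in this assay, most likely between 38% and 78%.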

Compound 4, a percentage reported as inhibition, at one concentration (the size of the read-out at that concentration, not a potency): 58.6%
Beside the measured number, compound 4's estimate is 0.6 percentage points below it; low and high end bracket the measured number.
By their numbers in this assay, from the lowest: compounds 3, 4, 1 and 2 (each within the scatter of the next, the first and the last beyond it).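

Within the data shown here, this is the first pair that differs in one place only, so the exchange on this aromatic carbon can now be read by itself: this assay shows a number 2.6 percentage points lower from compound 1 to compound 4 (within the scatter) and nothing larger. Pyridin-2-yl brings a ring nitrogen and a hydrogen-bond acceptor where 3-chlorophenyl has a chlorine and no acceptor, yet compound 4 cannot be told apart from compound 1, so at the one concentration tested this position on the five-membered aromatic ring accepts the exchange without a shift that stands out from the scatter. No measurement at hand explains why the two groups read alike.

From the compounds shown here alone, a single exchange says little about groups of another kind, and whether an amine, a carboxylic acid or a longer alkyl chain on this carbon would move the number beyond the scatter stays open. Also open is whether pyridin-2-yl would read the same alongside the other substituents carried by compound 2 and compound 3, and a reading at one concentration gives no potency for any of these compounds.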